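Nitrile to Trifluoromethyl at the Cytotoxicity Limit

The compounds below may be only part of what the source reports. "The series", "measured", "known", "first", "only" and "open" are said of these compounds alone.

The measured compounds, each in a functional assay on A549 cells (Homo sapiens) for cytotoxicity, read by CCK-8 assay, with a stated time of 24 h; a lower number here means a stronger inhibitor, a higher number a weaker inhibitor:
Compound 1, `C/C(=C\c1cc(-c2ccccc2)cs1)C(N)=O`, gives only the assay limit, > 50000 nM.
Compound 2, `C/C(=C\c1cc(-c2ccc(C)cc2)cs1)C(N)=O`, gives only the assay limit, > 50000 nM.
Compound 3, `C/C(=C\c1cc(-c2ccc(C#N)cc2)cs1)C(N)=O`, gives only the assay limit, > 50000 nM.

Compound 3 therefore stands nowhere distinct on the numbers shown: its value is a limit and not a number, and the same holds for the two others, as the limit of > 50000 nM in this assay, at which 3 of the 3 values shown sit, records. The three steps among the measured compounds are a step that the two limits leave unreadable from compound 1 to compound 2, a step that the two limits leave unreadable from compound 1 to compound 3 and a step that the two limits leave unreadable from compound 2 to compound 3; none has a readable size.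

Compound 4, `C/C(=C\c1cc(-c2ccc(C(F)(F)F)cc2)cs1)C(N)=O`, differs from compound 3 by trifluoromethyl in place of cyano on an aromatic carbon. Among the measured compounds shown here, the steps that bear on this swap are the substituent changes among compounds 1, 2 and 3, and all of them are unreadable, so no step of any direction beyond the scatter can be read from them. For the measured compounds named here, the expected step is a step that the limit leaves unreadable from compound 3 to compound 4, which is essentially no step. Compound 4 is accordingly estimated in this assay at 70000 nM, with a range from 30000 nM to 250000 nM, and most likely the assay again reports only a limit.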

Compound 4, half-maximal inhibitory concentration: > 50000 nM
Compound 4 gave a limit, no number (the forecaster's own chance of this, stated with the estimate: 85%); the middle value is on the limit's open side.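

Among the compounds shown here, compound 4 gives > 50000 nM, which is a limit and not a number, so no step from compound 1, compound 2 or compound 3 to compound 4 can be read. All four compounds share one result: the limit of > 50000 nM in this assay, at which 4 of the 4 values shown sit. The compounds shown leave open whether hydrogen, methyl, cyano and trifluoromethyl differ in cytotoxicity at all.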